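Pyrazoline sulfonamides: trimethoxyphenyl in place of phenyl

The source may report more compounds than this note shows. Statements on the series, on what has been measured and on what is new or still open speak of the compounds shown alone.

Compound 2 `COc1cc(C)c(Cl)cc1C1=NN(c2ccc(S(N)(=O)=O)cc2)C(c2ccccc2)C1` gives 55.3% in a functional assay on the whole organism (strain Wistar) for inhibition, with Rattus norvegicus as the target, read by paw edema, with stated times of 30 min and 3 h, at a dose of 20 mg/kg by the oral route (on this read-out lower numbers stand for less inhibition and higher numbers for more inhibition at the one dose given (going by the name of the read-out)), the larger of the two numbers shown. Compound 1 `Cc1cc(O)c(C2=NN(c3ccc(S(N)(=O)=O)cc3)C(c3ccccc3)C2)cc1Cl` gives 47.4%; the step of a number 7.9 percentage points higher from compound 1 to compound 2 (within the scatter) is within the scatter, so the two compounds are not separated. Compound 3 `COc1cc(C)c(Cl)cc1C1=NN(c2ccc(S(N)(=O)=O)cc2)C(c2ccc(OC)c(OC)c2OC)C1` differs from compound 2 by 2,3,4-trimethoxyphenyl in place of phenyl on a saturated ring carbon. Within the data shown here, no measured step touches this position, so there is nothing to scale an expectation from; the change is therefore expected to give no step beyond the scatter, a number 1.7 percentage points higher from compound 2 to compound 3 (within the scatter). Compound 3 is estimated at 57%, with a range of 35% to 76%.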

Compound 3, a percentage reported as inhibition, in the whole organism at one dose (the size of the read-out at that dose, not a potency): 34.2%
Compound 3: middle estimate off by 22.8 percentage points, on the high side; the measured number lies below the stated range.
By their numbers in this assay, from the lowest: compound 3; then compounds 1 and 2 (each within the scatter of the next).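

The saturated ring carbon next to the ring nitrogen does respond to substitution: in this assay, 2,3,4-trimethoxyphenyl in place of phenyl gives a number 21.1 percentage points lower from compound 2 to compound 3 (beyond the scatter). The only other step shown, methyl in place of hydrogen on an oxygen on an aromatic ring, stays within the scatter, so this is the first change in the series to separate two compounds. Nothing available bears on the reason for this drop.

Open, going by these compounds, is whether phenyl carrying a single methoxy, an amine or a carboxylic acid at this position would behave like the phenyl of compound 2 or the 2,3,4-trimethoxyphenyl of compound 3. Also open, on these data alone, is whether the same change would give a similar step on compound 1.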